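A few compounds are considered here, and "the series" means these few. Any claim that something is new, unique, unknown or untested is made for them only; others in the source may bear on it.

Compound 2 `COc1cc(-c2nn(-c3cccc(NC(=O)Nc4ccc(Cl)c(Cl)c4)c3)cc2-c2ccncc2)ccc1Cl` sits at the upper edge of the numbers gathered here. In a functional assay on RPMI-8226 cells (Homo sapiens) for inhibition, read by sulforhodamine B assay, with a stated time of 48 h (a higher number here means that more compound is tolerated, a lower number that less compound is tolerated), compound 2 gives only a limit, > 50000 nM. Compound 1 `COc1cc(-c2nn(-c3cccc(NC(=O)c4cccc(C(F)(F)F)c4)c3)cc2-c2ccncc2)ccc1Cl` likewise gives only a limit, > 50000 nM. Compound 3 `O=C(Nc1cccc(-n2cc(-c3ccncc3)c(-c3ccc(Cl)c(O)c3)n2)c1)Nc1ccc(Cl)c(Cl)c1` also gives only a limit, > 32500 nM. The two measured steps, a step that the two limits leave unreadable from compound 1 to compound 2 and a step that the two limits leave unreadable from compound 2 to compound 3, cannot be read in size, since all three values rest on the limit of > 50000 nM in this assay, at which 2 of the 3 values shown sit, or (the limit of > 32500 nM in this assay, at which 1 of the 3 values shown sits). Compound 4 `COc1cc(-c2nn(-c3cccc(NC(=O)c4ccc(Cl)c(C(F)(F)F)c4)c3)cc2-c2ccncc2)ccc1Cl` differs from compound 2 by 4-chloro-3-(trifluoromethyl)phenyl in place of (3,4-dichlorophenyl)amino on a carbonyl carbon. Neither measured step is readable, so no step size can be carried over to this change, and the expected step from compound 2 to compound 4 is a number no higher from compound 2 to compound 4 (the limit leaves the size open). Compound 4 is therefore estimated at 50000 nM, within 15000 nM to 100000 nM, most likely reported again only as a limit in this assay.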

Compound 4, concentration lethal to 50% of the cells: > 32500 nM
Compound 4 was reported as a limit (the forecaster's own chance of this, stated with the estimate: 80%); the middle value lies beyond the limit too.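

Compound 4, like compound 1 and compound 2, gives only a limit, and neither new step can be read in size. The compounds shown leave open where any of the four compounds actually lies in this assay.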